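This account rests on a few compounds, and the source may have more. Where it says the series, first, only, none or still open, it means among the compounds named here.

Compound 1 `Cc1ccc(CSc2nc3nc(C)cc(Nc4cc(-c5ccccc5)[nH]n4)n3n2)cc1`: in a functional assay on MGC-803 cells (Homo sapiens) for inhibition, read by MTT assay, with a stated time of 72 h (a lower number here means a stronger inhibitor, a higher number a weaker inhibitor), compound 1 gives 6960 nM.
Compound 2 `Cc1cc(Nc2cc(-c3ccccc3)[nH]n2)n2nc(SCc3cccc(Br)c3)nc2n1`: in this assay compound 2 gives 4820 nM.

Compound 1 stands with the higher of the two numbers, yet the step of a 1.4-fold lower number from compound 1 to compound 2 (0.16 log units; within the scatter) lies within the scatter, so the two compounds are not told apart. Compound 3 `CCCSc1nc2nc(C)cc(Nc3cc(-c4ccccc4)[nH]n3)n2n1` differs from compound 1 by ethyl in place of 4-methylphenyl on a saturated chain carbon bound to a sulfur. Among the measured compounds shown here, the only measured step exchanges 4-methylphenyl for 3-bromophenyl and was small; no measured step removes the ring altogether, so the data bear only loosely on this change. Compound 3 is therefore expected to shift by a 1.3-fold higher number from compound 1 to compound 3 (0.11 log units; within the scatter), a step within the scatter. Compound 3 is estimated at 9000 nM, with a range from 3500 nM to 23000 nM.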

Compound 3, half-maximal inhibitory concentration: 12600 nM
The estimate for compound 3 lay 1.4-fold (0.15 log units) below the measured number, and the stated range covers the measured number.
By their numbers in this assay, from the lowest: compounds 2, 1 and 3 (each within the scatter of the next, the first and the last beyond it).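

Replacing the 4-methylphenyl with ethyl on the saturated chain carbon bound to a sulfur gives a 1.8-fold higher number from compound 1 to compound 3 (0.26 log units; within the scatter), so this exchange cannot be told from repeat measurement. Among the compounds shown here, replacing the 3-bromophenyl with ethyl at the same place gives a 2.6-fold higher number from compound 2 to compound 3 (0.42 log units; beyond the scatter), the first step here to pass the scatter, showing that this position responds, though modestly, to what it carries. Nothing measured here explains that difference.

On these data alone, whether an amine, a carboxylic acid or a longer chain at this place would move the number further remains open.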